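Amide nitrogen substituent swap in a cytotoxicity series

The source may report more compounds than this note shows. Statements on the series, on what has been measured and on what is new or still open speak of the compounds shown alone.

Compound 1 `C=CC1=C(C(=O)NC2CCCCC2)C(c2ccc(OC)c(OC)c2)OC1` belongs to a small set of amides sharing one core. In a functional assay on A549 cells (Homo sapiens) for cytotoxicity, read by MTT assay, with a stated time of 24 h (a lower number here means a stronger inhibitor, a higher number a weaker inhibitor), compound 1 gives > 100000 nM, which is a limit of the assay and not a number. Compound 2 `C=CC1=C(C(=O)NC2CCCCC2)C(c2ccc(OC)cc2)OC1` is the nearest neighbour, differing from compound 1 by hydrogen in place of methoxy on an aromatic carbon. In this assay compound 2 gives > 100000 nM, again a limit. The step that the two limits leave unreadable from compound 1 to compound 2 is therefore not readable. Compound 3 `C=CC1=C(C(=O)Nc2cccc(C)c2)C(c2ccc(F)cc2)OC1` differs from compound 1 in more than one place. In this assay compound 3 gives > 100000 nM, also a limit. For the measured compounds named here, all three measured values sit at the same limit (the limit of > 100000 nM in this assay, at which 3 of the 3 values shown sit), so no measured step in the set has a readable size.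

Compound 4 `C=CC1=C(C(=O)Nc2ccccc2)C(c2ccc(OC)c(OC)c2)OC1` has not yet been measured. It differs from compound 1 by phenyl in place of cyclohexyl on an amide-type nitrogen. Going by the values given here, no measured step covers this change; compound 3, which also carries an aromatic group on an amide-type nitrogen, sits at the limit like compound 1 and compound 2. The step that the limit leaves unreadable from compound 1 to compound 4 is therefore expected to be none beyond the scatter, with the limit the most likely outcome. For compound 4 the estimate in this assay is 150000 nM, in a range from 50000 nM to 500000 nM.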

Compound 4, half-maximal inhibitory concentration: > 100000 nM
Compound 4: no number, only a limit; the forecaster's own chance of this, stated with the estimate: 85%; the middle value is on the limit's open side.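

In this assay compound 4 gives > 100000 nM and that is a limit, not a number; the change from compound 1 to compound 4 therefore has no readable size: the limit of > 100000 nM in this assay, at which 4 of the 4 values shown sit.

The compounds shown leave open whether any amide on the shared core gives a measurable value in this assay and what a change on the amide-type nitrogen would then do.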